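Methoxyphenyl series: positional swap on the pendant ring

A few compounds are considered here, and "the series" means these few. Any claim that something is new, unique, unknown or untested is made for them only; others in the source may bear on it.

Measured so far:
compound 1, `COc1ccc(C)c(-c2cccc(COc3ccc(OCC(=O)O)c(F)c3)c2)c1`: 260 nM
compound 2, `COc1cccc(-c2cccc(COc3ccc(OCC(=O)O)c(F)c3)c2)c1`: 540 nM
compound 3, `O=C(O)COc1ccc(OCc2cccc(-c3cccc(OCC4CC4)c3)c2)cc1F`: 670 nM

All three share the same acid-bearing core and were run in a functional assay on CHO cells for agonist activity at Free fatty acid receptor 1 (Homo sapiens), read by FLIPR and calcium flux; on this read-out lower numbers stand for an effect already at smaller amounts and higher numbers for an effect only at larger amounts of compound. Compound 2 holds the second highest of the three numbers; it sits within the scatter of compound 3 (a 1.2-fold higher number from compound 2 to compound 3 (0.09 log units; within the scatter)) and is separated from compound 1 by a step beyond the scatter (a 2.1-fold higher number from compound 1 to compound 2 (0.32 log units; beyond the scatter)).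

Compound 4, `COc1ccc(-c2cccc(COc3ccc(OCC(=O)O)c(F)c3)c2)cc1`, has not yet been run in this assay. It differs from compound 2 by 4-methoxyphenyl in place of 3-methoxyphenyl on an aromatic carbon; the same atoms are present, joined differently. Within the data shown here, no measured step moves the methoxy group around the pendant ring, so none bears directly on this change. The two steps that are known, the loss of a methyl (a 2.1-fold higher number from compound 1 to compound 2 (0.32 log units; beyond the scatter)) and the exchange of hydrogen for cyclopropyl on the chain carbon (a 1.2-fold higher number from compound 2 to compound 3 (0.09 log units; within the scatter)), are both modest or within the scatter, which suggests this end of the molecule tolerates small rearrangements without large shifts.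

Compound 4 is therefore expected to land close to compound 2, with the step of a 1.0-fold higher number from compound 2 to compound 4 (0.01 log units; within the scatter) estimated as within the scatter. The estimate for compound 4 in this assay is 550 nM, with a range of 220 nM to 1400 nM.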

Compound 4, half-maximal effective concentration: 170 nM
Compound 4: the middle estimate sits 3.2-fold (0.51 log units) above what was measured; measured number below the stated range.
By their numbers in this assay, from the lowest: compounds 4 and 1 (each within the scatter of the next); then compounds 2 and 3 (each within the scatter of the next).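

In this assay, among these compounds, moving the methoxy group on the pendant ring changes neither the atoms nor the counts of the group, yet it gives a 3.2-fold lower number from compound 2 to compound 4 (0.50 log units; beyond the scatter), so this place responds to where the methoxy group stands, which the earlier steps, all made by adding or exchanging atoms, could not show. The other new step, a 1.5-fold lower number from compound 1 to compound 4 (0.18 log units; within the scatter), lies within the scatter, so the 4-methoxyphenyl group without any methyl group and the 5-methoxy-2-methylphenyl group cannot be told apart on this read-out, and the methyl group of compound 1 is not needed to reach that level once the methoxy group is placed as in compound 4. The compounds shown offer no measured basis for explaining the difference between the 3-methoxyphenyl and 4-methoxyphenyl groups.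

Open, going by these compounds, is whether the 4-methoxyphenyl result extends to other groups on the same aromatic carbon, such as 4-ethoxyphenyl, 4-trifluoromethoxyphenyl or 4-cyanophenyl. Also open, on these data alone, is whether a methyl group or the cyclopropyl exchange seen in compound 3 would act the same way on the 4-methoxyphenyl arrangement as on the 3-methoxyphenyl arrangement, and whether any gain seen there would add to that of compound 4.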